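A few compounds are considered here, and "the series" means these few. Any claim that something is new, unique, unknown or untested is made for them only; others in the source may bear on it.

Measured compounds:
compound 1 `COC(=O)Cn1cc(Nc2ncnc3ccc(-c4cnc(OC)c(NS(=O)(=O)c5ccc(F)cc5F)c4)cc23)cn1` — 670 nM
compound 2 `CCCCS(=O)(=O)Nc1cc(-c2ccc3ncnc(Nc4ccc(OCCO)nc4)c3c2)cnc1OC` — > 20000 nM
compound 3 `COC(=O)CCn1cc(Nc2ncnc3ccc(-c4cnc(OC)c(NS(C)(=O)=O)c4)cc23)cn1` — 490 nM

In a functional assay on MCF7 cells (Homo sapiens) for antiproliferative activity, read by sulforhodamine B assay, with a stated time of 72 h (on this read-out lower numbers stand for stronger inhibition and higher numbers for weaker inhibition), compound 1 gives 670 nM, the higher of the two numbers obtained. Compound 3 gives 490 nM, and the gap between compound 3 and compound 1 lies within the usual scatter, so the two cannot be told apart. For compound 2 the result is only a limit, > 20000 nM; one of the three results sits at the limit of > 20000 nM in this assay, at which 1 of the 3 values shown sits.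

Compound 4 `COc1ncc(-c2ccc3ncnc(Nc4cnn(CCCO)c4)c3c2)cc1NS(=O)(=O)c1ccc(F)cc1F` has not yet been measured. It differs from compound 1 in one place: 2-hydroxyethyl in place of methoxycarbonyl on a saturated chain carbon bound to an aromatic nitrogen. Within the data shown here, no measured pair shows this kind of change, so the step from compound 1 to compound 4 is expected to be small, in either direction or none beyond the scatter, giving a 1.1-fold lower number from compound 1 to compound 4 (0.05 log units; within the scatter). Compound 4 is therefore estimated at 600 nM, within 250 nM to 1500 nM.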

Compound 4, half-maximal inhibitory concentration: 1310 nM
Compound 4: the middle estimate sits 2.2-fold (0.34 log units) below what was measured, within the range that was stated.
By their numbers in this assay, from the lowest: compounds 3, 1 and 4 (each within the scatter of the next, the first and the last beyond it). At a limit, above all of these: compound 2.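

In this assay the first single-place comparison gives a 2.0-fold higher number from compound 1 to compound 4 (0.29 log units; within the scatter), so 2-hydroxyethyl in place of methoxycarbonyl on this saturated chain carbon cannot be told apart from no change. The swap brings in a hydrogen-bond donor where the group that leaves has none, and the read-out stays within the scatter. Nothing measured here offers a reason for this.

As far as these compounds go, whether an amine or a carboxylic acid in this place would read the same remains open. So does the effect of a longer chain.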